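This account rests on a few compounds, and the source may have more. Where it says the series, first, only, none or still open, it means among the compounds named here.

Compounds measured so far:

Compound 1, `CCOC(=O)c1c(NC(=O)CC#N)sc(C(=O)Nc2ccc(Cl)cc2)c1-c1ccccc1`, gives 620 nM in a functional assay on HT-29 cells (Homo sapiens) for inhibition, read by MTT assay; on this read-out higher numbers stand for weaker inhibition and lower numbers for stronger inhibition.
Compound 2, `N#CCC(=O)Nc1sc(C(=O)Nc2ccc(Cl)cc2)c(-c2ccccc2)c1C#N`, gives 860 nM in this assay.

Among these two numbers, compound 2 stands at the higher one, but its nearest neighbour, compound 1, differs by a 1.4-fold higher number from compound 1 to compound 2 (0.14 log units; within the scatter), so the two compounds are not separated on this read-out.

Compound 3, `N#CCC(=O)Nc1sc(C(=O)Nc2ccccc2)c(-c2ccccc2)c1C#N`, has not yet been measured in this assay. It differs from compound 2 only at the aryl amide: hydrogen in place of chloro on an aromatic carbon. Within the data shown here, of the measured steps, only the one from compound 1 to compound 2 exists, and it concerns a different position, an ester giving way to a nitrile on the core, so it does not speak to the present change. Among the measured compounds shown here, no measured pair shows what removing the chloro from the anilide does here. With nothing to point either way, no step beyond the scatter is expected for compound 3 in this assay, and its potency is estimated to sit close to that of compound 2, which is a change of a 1.2-fold higher number from compound 2 to compound 3 (0.07 log units; within the scatter). Compound 3 is therefore expected to give about 1000 nM, with a plausible range from 400 nM to 2500 nM.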

Compound 3, half-maximal inhibitory concentration: 6590 nM
Estimate against measurement, compound 3: 6.6-fold (0.82 log units) below; measured number above the stated range.
By their numbers in this assay, from the lowest: compounds 1 and 2 (each within the scatter of the next); then compound 3.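

In this assay, the 4-chlorophenyl on the amide proves to matter: hydrogen in place of chloro gives a 7.7-fold higher number from compound 2 to compound 3 (0.88 log units; beyond the scatter). The only earlier step, the exchange of ethoxycarbonyl for cyano on the core, stayed within the scatter, so this is the first change among these compounds to separate two of them, and it involves the loss of a single chlorine atom from an aromatic carbon para to a large group. Nothing available here accounts for the size of this step, and what the chloro contributes to inhibition cannot be said.

The compounds shown give this result for one pair only, with a nitrile on the core, so it remains open whether the same change would have a similar effect with the ethoxycarbonyl of compound 1 in that place. They also leave open whether the requirement is specific to chloro, or whether fluoro, bromo, methyl or methoxy on the same carbon would keep inhibition at the level of compound 2 rather than compound 3.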